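The source may hold more compounds than are shown below. What is called first, only, known or untested is meant among the compounds shown, and "the series" means these compounds.

Measured in an ADME assay on the whole organism (plasma) for pharmacokinetics, with Rattus norvegicus as the target, with a stated time of 6 h, at a dose of 10 mg/kg by the oral route; a lower number here means less compound in the circulation, a higher number more compound in the circulation at the dose given:
compound 1 `FC(F)(F)c1cccc(-c2c[nH]c(-c3cccc(CN4CCCCC4)c3)n2)c1` — 207 ng.h/mL
compound 2 `CC1CCN(Cc2cccc(-c3nc(-c4cccc(C(F)(F)F)c4)c[nH]3)c2)CC1` — 352 ng.h/mL
compound 3 `CC1CCCN(Cc2cccc(-c3nc(-c4cccc(C(F)(F)F)c4)c[nH]3)c2)C1` — 564 ng.h/mL

Among the compounds with values here, compound 3 gives the highest number of the three in this assay; the gap to compound 2 is within the scatter, and only the step of a 2.7-fold higher number from compound 1 to compound 3 (0.44 log units; beyond the scatter) is beyond it. Compound 4 `FC1(F)CCN(Cc2cccc(-c3nc(-c4cccc(C(F)(F)F)c4)c[nH]3)c2)CC1` differs from compound 3 by 4,4-difluoropiperidin-1-yl in place of 3-methylpiperidin-1-yl on a saturated chain carbon bound to an aromatic carbon. Within the data shown here, no measured step exchanges one substituent on the saturated ring for another of a different kind; the nearest comparisons are a 2.7-fold higher number from compound 1 to compound 3 (0.44 log units; beyond the scatter) and a 1.6-fold higher number from compound 2 to compound 3 (0.20 log units; within the scatter), both changes on the saturated ring, and both of modest size or smaller. The exchange to 4,4-difluoropiperidin-1-yl lies outside what these steps cover. For compound 4 the expected step in this assay is a 1.4-fold lower number from compound 3 to compound 4 (0.15 log units; within the scatter), not beyond the scatter. Compound 4 is therefore estimated at 400 ng.h/mL, between 150 ng.h/mL and 1000 ng.h/mL.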

Compound 4, area under the concentration-time curve: 468 ng.h/mL
Compound 4: middle estimate off by 1.2-fold (0.07 log units), on the low side; the measured number falls inside the stated range.
By their numbers in this assay, from the lowest: compounds 1, 2, 4 and 3 (each within the scatter of the next, the first and the last beyond it).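

Within the data shown here, in (this assay), 4,4-difluoropiperidin-1-yl is the first group on the saturated ring to replace methyl with a different kind of substituent, and the number does not move beyond the scatter in either comparison (a 1.2-fold lower number from compound 3 to compound 4 (0.08 log units; within the scatter)) (a 1.3-fold higher number from compound 2 to compound 4 (0.12 log units; within the scatter)). Compared with the unsubstituted piperidin-1-yl, the exchange gives a modest gain (a 2.3-fold higher number from compound 1 to compound 4 (0.35 log units; beyond the scatter)), so compound 3 now has a second substituted ring beside it, while compound 2 remains within the scatter of compound 1. Nothing measured here explains these numbers.

From the compounds shown here alone, it remains open whether morpholine in place of the piperidine ring would stay in this range. The same question applies to a piperidine ring carrying a carboxylic acid or a primary amine.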